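This account rests on a few compounds, and the source may have more. Where it says the series, first, only, none or still open, it means among the compounds named here.

Compound 1 `CC1CCN(CC[C@H]2CCCN2S(=O)(=O)c2ccc3cc[nH]c3c2)CC1` is the reference point of this series. In an assay on HEK293 cells for binding affinity to 5-hydroxytryptamine receptor 7 (Homo sapiens), read by radioligand binding (a higher number here means a weaker inhibitor, a lower number a stronger inhibitor), compound 1 gives 2.4 nM, the lowest of the three numbers recorded. Compound 3 `CC1CCN(CC[C@H]2CCCN2S(=O)(=O)c2ccc3[nH]cnc3c2)CC1` carries a different fused bicyclic on the sulfonyl group and gives in this assay 6.46 nM, a step beyond the usual scatter. Compound 2 `CC1CCN(CC[C@H]2CCCN2S(=O)(=O)c2ccc3c(c2)NCC3)CC1`, with a partly saturated fused ring in that position, gives in this assay 22.9 nM, the furthest from compound 1 and also beyond the scatter. Compound 1 is therefore the strongest inhibitor measured so far.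

Compound 4 `O=C(c1ccc(F)cc1)C1CCN(CC[C@H]2CCCN2S(=O)(=O)c2ccc3cc[nH]c3c2)CC1` keeps the shared core of compound 1 and changes only the substituent on the six-membered saturated ring: (4-fluorophenyl)carbonyl in place of methyl on a saturated ring carbon. Within the data shown here, no measured pair in this set isolates such a change, so no step on that ring is known. Compound 4 is expected to stay close to compound 1 in this assay, with the step from compound 1 to compound 4 estimated at a 1.2-fold lower number from compound 1 to compound 4 (0.08 log units; within the scatter), either direction within or just beyond the scatter. The estimate for compound 4 is 2 nM, with a range from 0.5 nM to 8 nM.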

Compound 4, inhibition constant: 0.832 nM
Estimate against measurement, compound 4: 2.4-fold (0.38 log units) above, within the range that was stated.
By their numbers in this assay, from the lowest: compound 4; then compound 1; then compound 3; then compound 2.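

In this assay, (4-fluorophenyl)carbonyl in place of methyl on a saturated ring carbon gives a 2.9-fold lower number from compound 1 to compound 4 (0.46 log units; beyond the scatter), a modest step beyond the usual scatter. Among these compounds, this is the first measured change at this position, three ring bonds from the ring nitrogen, and it shows that a group of nine heavy atoms carrying an aromatic ring can replace a single carbon with no loss of binding, the number even falling. Nothing at hand gives a reason for this step.

The compounds shown leave open how the step divides among the carbonyl, the six-membered aromatic ring and the fluorine. Also open, from the compounds shown here alone, are how an amine or a carboxylic acid would fare on this ring carbon, and whether the step would carry over to the sulfonyl groups of compound 2 and compound 3.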